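The source may hold more compounds than are shown below. What is called first, only, known or untested is meant among the compounds shown, and "the series" means these compounds.

Measured so far:
Compound 1, `CCC(c1ccc(O)c(O)c1)c1ccc(O)c(OC)c1`: 96%
Compound 2, `CCC(c1ccc(O)c(OC)c1)c1cccc(O)c1O`: 94%
Compound 3, `CCC(c1ccc(O)c(OC)c1)c1ccc(O)cc1O`: 94%

Of the compounds shown here, three built on the same shared core have been tested in a functional assay for inhibition, with a stated time of 24 h, tested at 100 ug/mL; on this read-out lower numbers stand for less inhibition and higher numbers for more inhibition at the one concentration tested (going by the name of the read-out). In this assay compound 1 gives 96%. In the same read-out compound 2 gives 94%, and compound 3 gives 94%. Compound 2 stands level with compound 3 at the digits shown, and these two together hold the lowest of the three numbers; its nearest neighbour is compound 3, with no change at the digits shown, and its furthest is compound 1, whose higher number still lies within the usual scatter of this kind of measurement. All three numbers therefore sit close to one another near the top of the scale, and no single-point change between them has been worked out.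

Compound 4, `CCOc1cccc(C(CC)c2ccc(O)c(OC)c2)c1O`, has not yet been measured. It differs from compound 2 in one place: ethyl in place of hydrogen on an oxygen on an aromatic ring. Going by the values given here, with no step between measured compounds to lean on, and with compound 2 giving 94%, the expectation is that this change alters the read-out little. The expected step of a number 4 percentage points lower from compound 2 to compound 4 (within the scatter) is none beyond the scatter. Compound 4 is therefore estimated to give 90%, within a range from 72% to 98%.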

Compound 4, a percentage reported as inhibition, at one concentration (the size of the read-out at that concentration, not a potency): 96%
For compound 4 the middle estimate is 6 percentage points below the measured one; measured number inside the range.
By their numbers in this assay, from the lowest: compounds 2, 3, 1 and 4 (each within the scatter of the next).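

In this assay, going by these compounds alone, the hydroxy to ethoxy change, made on an oxygen on an aromatic ring, gives a number 2 percentage points higher from compound 2 to compound 4 (within the scatter), the only step here between two measured compounds that differ in one place. This shows that, at the one concentration tested, this position can carry ethyl in place of hydrogen without a shift beyond the usual scatter, so the free hydrogen on this oxygen is not needed to keep the read-out near the top of the scale. No supporting measurement is available to explain why the read-out holds up after this change.

Both compounds sit so close to the top of the scale that this single-concentration read-out cannot show whether they differ in potency, and a real difference could stay hidden at this level. Also open, going by these compounds, is whether the same oxygen would accept a longer chain such as butyl, or a chain ending in an amine or a carboxylic acid, and still keep the read-out this high.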